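Methylsulfanyl on the Aromatic Ring of a Nucleotide Agonist

The source may hold more compounds than are shown below. What is called first, only, known or untested is meant among the compounds shown, and "the series" means these compounds.

Measured compounds:
compound 1 `O=c1c2ccccc2ccn1[C@@H]1O[C@H](COP(=O)(O)OP(=O)(O)OP(=O)(O)O)[C@@H](O)[C@H]1O` — 31 nM
compound 2 `Cc1cccc2c(=O)n([C@@H]3O[C@H](COP(=O)(O)OP(=O)(O)OP(=O)(O)O)[C@@H](O)[C@H]3O)ccc12` — 557 nM
compound 3 `O=c1c2ccc(F)cc2ccn1[C@@H]1O[C@H](COP(=O)(O)OP(=O)(O)OP(=O)(O)O)[C@@H](O)[C@H]1O` — 77 nM

In a functional assay for agonist activity at P2Y purinoceptor 2 (Homo sapiens), read by FLIPR (a higher number here means that more compound is needed for the effect, a lower number that less compound is needed), compound 1 gives the lowest number of the three. Compound 3 stands nearest, a 2.5-fold higher number from compound 1 to compound 3 (0.40 log units; beyond the scatter), while compound 2 lies furthest away, an 18-fold higher number from compound 1 to compound 2 (1.25 log units; beyond the scatter). Both steps are beyond the scatter, so compound 1 is the most potent of the measured set.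

Compound 4 `CSc1ccc2ccn([C@@H]3O[C@H](COP(=O)(O)OP(=O)(O)OP(=O)(O)O)[C@@H](O)[C@H]3O)c(=O)c2c1` differs from compound 1 in one place: methylsulfanyl in place of hydrogen on an aromatic carbon. For the measured compounds named here, two measured steps bear on this change, since each also replaces a hydrogen on an aromatic carbon of the same core. The methyl step from compound 1 to compound 2 was large, and the fluoro step from compound 1 to compound 3 was modest. Methylsulfanyl, with its two heavy atoms, is larger than either group, and neither measured step went toward a lower number. The expectation for compound 4 in this assay is therefore a higher number than for compound 1, beyond the scatter, though its size is uncertain, so compound 4 is estimated at 200 nM with a range from 50 nM to 800 nM, corresponding to an expected step of a 6.5-fold higher number from compound 1 to compound 4 (0.81 log units; beyond the scatter).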

Compound 4, half-maximal effective concentration: 140 nM
Estimate against measurement, compound 4: 1.4-fold (0.15 log units) above, and the stated range covers the measured number.
By their numbers in this assay, from the lowest: compound 1; then compounds 3 and 4 (each within the scatter of the next); then compound 2.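

In this assay the methylsulfanyl group, on an aromatic carbon meta to a fused ring and para to a fused ring, gives a 4.5-fold higher number from compound 1 to compound 4 (0.65 log units; beyond the scatter) and adds a third case in which replacing a hydrogen on this aromatic ring raises the number. The step is modest, whereas the methyl change gives an 18-fold higher number from compound 1 to compound 2 (1.25 log units; beyond the scatter) and is large, even though methylsulfanyl is the bigger group, so across these compounds the size of the entering group does not by itself set the size of the step; the two groups also stand on different carbons of the shared core, and the place of substitution and the identity of the group cannot be separated here. Nothing available here accounts for the size of the new step.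

The compounds shown leave open whether the sulfur matters on this carbon, as a methoxy group or a methyl group there would show, and whether an amine or a carboxylic acid there would move the number in either direction. They also leave open whether methylsulfanyl would give a step of similar size on the carbons that carry the methyl of compound 2 or the fluoro of compound 3.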